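A few compounds are considered here, and "the series" means these few. Any claim that something is new, unique, unknown or untested is made for them only; others in the source may bear on it.

Measured so far:
- compound 1 `CCC(CC)n1c(-c2ccc(OCc3c(-c4c(Cl)cccc4Cl)noc3C(C)C)cc2)nc2ccc(C(=O)O)cc21` — 26.5 nM
- compound 2 `CC(C)c1onc(-c2c(Cl)cccc2Cl)c1COc1ccc(-c2nc3ccc(C(=O)O)cc3n2CC(C)(C)C)cc1` — 24.8 nM
- compound 3 `CC(C)c1onc(-c2c(Cl)cccc2Cl)c1COc1ccc(-c2nc3ccc(C(=O)O)cc3n2C2CC2)cc1` — 117 nM

All three share one core and differ only in the group carried on an aromatic nitrogen of that core. In an assay on isolated protein for agonist activity at Bile acid receptor (Homo sapiens), read by TR-FRET (a higher number here means that more compound is needed for the effect, a lower number that less compound is needed), compound 3 gives the highest number of the three: the step of a 4.4-fold higher number from compound 1 to compound 3 (0.64 log units; beyond the scatter) and the step of a 4.7-fold higher number from compound 2 to compound 3 (0.67 log units; beyond the scatter) both lie beyond the scatter, whereas the step of a 1.1-fold lower number from compound 1 to compound 2 (0.03 log units; within the scatter) is within it, so compounds 1 and 2 cannot be told apart.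

Compound 4 `CC(C)c1onc(-c2c(Cl)cccc2Cl)c1COc1ccc(-c2nc3ccc(C(=O)O)cc3n2CC2CC2)cc1` is the next member of this set. Its difference from compound 3 is cyclopropylmethyl in place of cyclopropyl on an aromatic nitrogen. Both steps that bear on it run from a larger branched alkyl to cyclopropyl and both raise the number by a modest amount; cyclopropylmethyl sits between cyclopropyl and those larger groups in its count of carbons. The step from compound 3 to compound 4 is therefore expected to lower the number, by less than the reverse of those two steps, as a 2.3-fold lower number from compound 3 to compound 4 (0.37 log units; beyond the scatter). Compound 4 is expected to give about 50 nM in this assay, with a plausible range from 22 nM to 115 nM.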

Compound 4, half-maximal effective concentration: 29.1 nM
For compound 4 the middle estimate is 1.7-fold (0.24 log units) above the measured one; the range from low to high includes it.
By their numbers in this assay, from the lowest: compounds 2, 1 and 4 (each within the scatter of the next); then compound 3.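

Cyclopropylmethyl in place of cyclopropyl on the aromatic nitrogen is a small change, from 3 to 4 heavy atoms with the three-membered ring kept, yet in this assay it gives a clear step (a 4.0-fold lower number from compound 3 to compound 4 (0.60 log units; beyond the scatter)). Compound 4 cannot be told apart from the compounds with larger alkyl groups, whether set against neopentyl (a 1.2-fold higher number from compound 2 to compound 4 (0.07 log units; within the scatter)) or against pentan-3-yl (a 1.1-fold higher number from compound 1 to compound 4 (0.04 log units; within the scatter)). Among these four compounds, then, the three-membered ring alone does not set compound 3 apart, since compound 4 carries it too, and branching of the kind found in neopentyl and pentan-3-yl is not needed to reach the level shared by compounds 1, 2 and 4.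

Still open, as far as these compounds go, is how far this level extends, for example to a straight butyl chain, a cyclobutylmethyl group, a plain methyl group, or a chain ending in an amine or a hydroxyl group. Nothing among the data shown explains why the cyclopropyl compound stands apart from the other three.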